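Lengthening the Side Chain: Compound 1 to Compound 3

The source may hold more compounds than are shown below. What is called first, only, known or untested is meant among the compounds shown, and "the series" means these compounds.

Within the data shown here, compound 1 `CCc1cc(C(C)=O)c(O)cc1OCCCCC#N` gives 57% in an assay on isolated protein for binding affinity to leukotriene B4 receptor 1 (Homo sapiens), tested at 1 uM (on this read-out higher numbers stand for more inhibition at the one concentration tested (going by the name of the read-out) and lower numbers for less inhibition), the highest of the two numbers measured so far. Compound 2 `CCCCc1cc(C(C)=O)c(O)cc1OCCCCC#N` gives 13% in this assay, and the step of a number 44 percentage points lower from compound 1 to compound 2 (beyond the scatter) is large. Compound 3 `CCCCCCc1cc(C(C)=O)c(O)cc1OCCCCC#N` differs from compound 1 by butyl in place of hydrogen on a saturated chain carbon, two bonds along the chain from an aromatic carbon. Among the measured compounds shown here, the only step that bears on this change, a number 44 percentage points lower from compound 1 to compound 2 (beyond the scatter), runs in the same direction with a shorter added chain, so a drop beyond the scatter is expected here as well. The value for compound 3 is estimated at 8%, between 0% and 25%. The expected step of a number 49 percentage points lower from compound 1 to compound 3 (beyond the scatter) would leave compound 3 near the low end of what has been measured.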

Compound 3, a percentage reported as inhibition, at one concentration (the size of the read-out at that concentration, not a potency): 13%
Estimate against measurement, compound 3: 5 percentage points below; the range from low to high includes it.
By their numbers in this assay, from the lowest: compounds 2 and 3 (each within the scatter of the next); then compound 1.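

In this assay, butyl in place of hydrogen on this saturated chain carbon gives a number 44 percentage points lower from compound 1 to compound 3 (beyond the scatter), whereas ethyl in place of hydrogen, four bonds along the chain from an aromatic carbon, gives no change at the digits printed from compound 2 to compound 3 (within the scatter). Across compounds 1, 2 and 3, the large loss therefore appears with the first added ethyl, and the further ethyl brings no additional change. Nothing available gives a reason for either step.

Still open, from the compounds shown here alone, is whether a longer chain stays level with compound 3. Going by these compounds, it is also open whether an amine or a carboxylic acid on this chain would recover the number of compound 1.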